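The source may report more compounds than this note shows. Statements on the series, on what has been measured and on what is new or still open speak of the compounds shown alone.

Measured so far in a functional assay on A549 cells (Homo sapiens) for cytotoxicity, read by MTT assay, with a stated time of 48 h; a lower number here means a stronger inhibitor, a higher number a weaker inhibitor:
- compound 1 `C=C1CCC[C@]2(C)CCC(c3cn(-c4ccc(OC)cc4)nn3)=CC[C@@]12C`: 34700 nM
- compound 2 `C=C1CCC[C@]2(C)CCC(c3cn(-c4ccccc4C(C)=O)nn3)=CC[C@@]12C`: 37700 nM

Going by the values given here, only one step joins these two measurements: a 1.1-fold higher number from compound 1 to compound 2 (0.04 log units; within the scatter). Among the compounds with values here, putting 2-acetylphenyl where 4-methoxyphenyl stood therefore moved nothing beyond the scatter, and compound 2 stands level with the only other measured compound.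

Next comes compound 3 `C=C1CCC[C@]2(C)CCC(c3cn(-c4cccc(OC)c4)nn3)=CC[C@@]12C`, which keeps the shared core and changes only the group on the aromatic nitrogen, with 3-methoxyphenyl in place of 2-acetylphenyl on an aromatic nitrogen. Within the data shown here, the one measured step bears directly on this, as it changed the same place. Two compounds are thin evidence, and neither carries 3-methoxyphenyl. Still, nothing measured points to a shift, so no change beyond the scatter is expected in this assay. The expected step is a 1.0-fold lower number from compound 2 to compound 3 (0.02 log units; within the scatter). For compound 3 the estimated value is 36000 nM, with an expected range of 17000 nM to 75000 nM.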

Compound 3, half-maximal inhibitory concentration: 11200 nM
The estimate for compound 3 lay 3.2-fold (0.51 log units) above the measured number, and the stated range ends above it.
By their numbers in this assay, from the lowest: compound 3; then compounds 1 and 2 (each within the scatter of the next).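

In this assay, the group on the aromatic nitrogen can change the result after all: a 3.4-fold lower number from compound 2 to compound 3 (0.53 log units; beyond the scatter), a modest step beyond the scatter, whereas the earlier swap at this place was not. The comparison with the closest relative is more telling, since a 3.1-fold lower number from compound 1 to compound 3 (0.49 log units; beyond the scatter), and 3-methoxyphenyl and 4-methoxyphenyl carry the same atoms, so where the methoxy sits on the phenyl ring matters here, and compound 3 is the strongest of the three. No supporting measurement is available to explain this difference.

From the compounds shown here alone, it remains open whether 2-methoxyphenyl would behave like either of these groups. It is also unclear whether the lower number depends on methoxy itself or would persist with 3-ethoxyphenyl, 3-aminophenyl or 3-carboxyphenyl in its place.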